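This account rests on a few compounds, and the source may have more. Where it says the series, first, only, none or still open, it means among the compounds named here.

Of the compounds shown here, three of a shared core have been measured in a physicochemical assay for solubility, in phosphate buffer, measured as kinetic solubility, with a stated time of 1 h, at pH 7.4; on this read-out higher numbers stand for higher solubility and lower numbers for lower solubility. Compound 1 `CSc1ccc2nc(C)cc(OCC(=O)Nc3cc(C)cc(C)c3)c2c1` gives 3000 nM. Compound 2 `COc1ccc2nc(C)cc(OCC(=O)NCc3cc(C)cc(C)c3)c2c1` gives 92000 nM. Compound 3 `COc1ccc2nc(C)cc(OCCNc3cc(C)cc(C)c3)c2c1` gives 33000 nM. Compound 2 stands highest of the three: compound 3 is nearest, and its number lies beyond the scatter below that of compound 2, while compound 1 is furthest, also beyond the scatter. Among the measured compounds shown here, compound 1 and compound 2 differ in more than one place, so no single step is drawn between them; their two values simply show the spread of the series.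

The next compound, compound 4 `COc1ccc2nc(C)cc(OCC(=O)Nc3ccc(Cl)c(OC)c3)c2c1`, has not yet been measured. It differs from compound 2 in one place: 4-chloro-3-methoxyphenyl in place of 3,5-dimethylbenzyl on an amide-type nitrogen.

For the measured compounds named here, no measured pair in this set isolates this change, so the expectation rests on the whole picture. Since compound 1 gives 3000 nM and compound 2 gives 92000 nM, the series spans a wide range, and a downward step of moderate size beyond the scatter is expected from compound 2 to compound 4, as a 6.1-fold lower number from compound 2 to compound 4 (0.79 log units; beyond the scatter). On that basis compound 4 is expected to give about 15000 nM in this assay, within a range from 4000 nM to 50000 nM.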

Compound 4, solubility: 13000 nM
Compound 4: the middle estimate sits 1.2-fold (0.06 log units) above what was measured; low and high end bracket the measured number.
By their numbers in this assay, from the lowest: compound 1; then compound 4; then compound 3; then compound 2.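

In this assay, among the compounds shown here, 4-chloro-3-methoxyphenyl in place of 3,5-dimethylbenzyl on the amide-type nitrogen gives a 7.1-fold lower number from compound 2 to compound 4 (0.85 log units; beyond the scatter), the first step in this set that isolates a change at one place, so the group at this position is now seen to move the read-out by itself, with the rest of the molecule held constant. The size of the step is notable given how much the two groups share: each has 9 heavy atoms and one six-membered aromatic ring of carbon only, though the entering group carries 1 hydrogen-bond acceptor and the leaving group 0 hydrogen-bond acceptors. Nothing available here explains why the number falls.

The compounds shown leave open how this step divides between the swap from a benzyl to a phenyl group and the swap of the two methyl groups for chloro and methoxy, since both changes arrive together. As far as these compounds go, a 4-chloro-3-methoxybenzyl group at this place would separate the two, and the effect of an amine such as a morpholinylethyl group or of a carboxylic acid here also remains open.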